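Methylating the Sulfonamide Nitrogen of a Weak Agonist Series

A few compounds are considered here, and "the series" means these few. Any claim that something is new, unique, unknown or untested is made for them only; others in the source may bear on it.

Among the measured compounds shown here, compound 1 `O=C(Nc1ccc(S(=O)(=O)Nc2ccccc2Cl)cc1)c1ccc(Cl)cc1Cl` is the only member of this set with a numerical result: in a functional assay on HEK293 cells for agonist activity at probable G-protein coupled receptor 27 (Homo sapiens), read by a luciferase reporter and beta-arrestin recruitment, with a stated time of 10 min (on this read-out higher numbers stand for an effect only at larger amounts of compound and lower numbers for an effect already at smaller amounts), compound 1 gives 1260 nM. Compound 2 `Cc1ccc(NS(=O)(=O)c2ccc(NC(=O)c3ccc(Cl)cc3Cl)cc2)cc1` reaches only the limit of > 100000 nM in this assay. Compound 3 `O=C(Nc1ccc(S(=O)(=O)NCc2ccccc2)cc1)c1ccc(Cl)cc1Cl` likewise stands at the limit of > 100000 nM. The measured shifts were an at least 79-fold higher number from compound 1 to compound 2 (1.89 log units; beyond the scatter) and an at least 79-fold higher number from compound 1 to compound 3 (1.89 log units; beyond the scatter), while a step that the two limits leave unreadable from compound 2 to compound 3. For the measured compounds named here, compound 4 `CN(c1ccccc1)S(=O)(=O)c1ccc(NC(=O)c2ccc(Cl)cc2Cl)cc1` differs from compound 3 by methyl(phenyl)amino in place of benzylamino on a sulfonyl sulfur, a change no measured pair covers. Since compound 3 sits at the limit of > 100000 nM in this assay, at which 2 of the 3 values shown sit, the step of a number no higher from compound 3 to compound 4 (the limit leaves the size open) is expected to remain unreadable in this assay, with no sign of a return to numerical potency. Compound 4 is accordingly estimated at 100000 nM, within 20000 nM to 300000 nM.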

Compound 4, half-maximal effective concentration: 2570 nM
Compound 4: the middle estimate sits 39-fold (1.59 log units) above what was measured; the whole stated range lies above it.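

With methyl(phenyl)amino on the sulfonyl sulfur, a numerical result returns, giving an at least 38-fold lower number from compound 3 to compound 4 (1.59 log units; beyond the scatter) and an at least 38-fold lower number from compound 2 to compound 4 (1.59 log units; beyond the scatter). Compared with the (2-chlorophenyl)amino group, the change is far smaller, with a 2.0-fold higher number from compound 1 to compound 4 (0.31 log units; beyond the scatter). A hydrogen-bond donor at this place is therefore not required for a numerical result in this assay, and the presence of a phenyl group alone does not decide the outcome. Going by these compounds, the sizes of the large steps stay open, as two compounds remain at a limit: the limit of > 100000 nM in this assay, at which 2 of the 4 values shown sit. On these data alone, whether an ethyl group in place of the methyl, or a chlorine on the phenyl ring of compound 4, would lower the number also remains open.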